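A Pyrimidine Replaces a Pyrazole on a Shared Core

A few compounds are considered here, and "the series" means these few. Any claim that something is new, unique, unknown or untested is made for them only; others in the source may bear on it.

Measured compounds in an assay on cells for inhibition of S-adenosylmethionine decarboxylase proenzyme (Homo sapiens), read by mass spectrometry, at pH 7.2; a lower number here means a stronger inhibitor, a higher number a weaker inhibitor:
Compound 1, `Cc1cc(Nc2cc(Cl)cc(-c3ccc(C#N)cc3)c2)nc(N)n1`, gives > 7000 nM, which is a limit of the assay.
Compound 2, `Cc1cc(Nc2cc(Cl)cc(-c3cnn(C)c3)c2)nc(N)n1`, gives > 180000 nM, which is also a limit of the assay.

Compound 2 therefore stands at a limit in this assay, with no actual number known for it. Among the measured compounds shown here, the only measured step, a step that the two limits leave unreadable from compound 1 to compound 2, cannot be read in size because the limit of > 180000 nM in this assay, at which 1 of the 2 values shown sits, and the limit of > 7000 nM in this assay, at which 1 of the 2 values shown sits, are both limits rather than numbers. Compound 3, `Cc1cc(Nc2cc(Cl)cc(-c3cncnc3)c2)nc(N)n1`, differs from compound 2 by pyrimidin-5-yl in place of 1-methyl-1H-pyrazol-4-yl on an aromatic carbon. For the measured compounds named here, no measured step resembles this change, and the one step that exists gives no size at all, so there is no basis to expect a step beyond the usual scatter in either direction. The expected value of compound 3 in this assay is 200000 nM, estimated to lie between 40000 nM and 1000000 nM, and most likely reported once more only as a limit. The step this estimate implies, a step that the limit leaves unreadable from compound 2 to compound 3, is expected to be no more than the scatter.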

Compound 3, half-maximal inhibitory concentration: > 180000 nM
Compound 3 gave a limit, no number; the forecaster's own chance of this, stated with the estimate: 85%; the middle value is on the limit's open side.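

Among the compounds shown here, the values of compound 1, compound 2 and compound 3 are all limits of the assay rather than numbers, so no step among them can be read in size. The compounds shown leave open how strongly any of them inhibits the enzyme, and whether 4-cyanophenyl, 1-methyl-1H-pyrazol-4-yl and pyrimidin-5-yl differ at all on the shared core.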